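Dropping the Chloro Group: What to Expect for Compound 4

The source may report more compounds than this note shows. Statements on the series, on what has been measured and on what is new or still open speak of the compounds shown alone.

Compound 1 `COc1cc(/C=C/C(=O)c2cccc(-n3cc(-c4ccc(Cl)cc4)[nH]c3=O)c2)cc(OC)c1OC` was examined in a functional assay on A549 cells (Homo sapiens) for inhibition (on this read-out lower numbers stand for stronger inhibition of growth and higher numbers for weaker inhibition of growth), and there compound 1 gives "not active" (no number reported), so no single number places it among its relatives. Two relatives do carry numbers. In this assay compound 2 `COc1cc(/C=C/C(=O)c2cccc(-n3cc(-c4ccccc4)[nH]c3=O)c2)ccc1O` gives 3850 nM. In this assay compound 3 `O=C(/C=C/c1cccc(O)c1)c1cccc(-n2cc(-c3ccc(Cl)cc3)[nH]c2=O)c1` gives 3550 nM. These two values lie close to each other, within the usual scatter, so neither is set above the other.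

Compound 4 `COc1cc(/C=C/C(=O)c2cccc(-n3cc(-c4ccccc4)[nH]c3=O)c2)cc(OC)c1OC` is the member still to be measured. It differs from compound 1 by hydrogen in place of chloro on an aromatic carbon, in words hydrogen in place of chloro on an aromatic carbon. For the measured compounds named here, no step between two measured compounds matches this change, so its size and direction are not known from the data, and compound 1 offers no number to move from. Compound 2 also lacks the chloro group and has a number, while compound 3 keeps it and has one as well; no more than that can be read from them.

Compound 4 is therefore expected to show only weak inhibition of growth, with an estimated value of 9000 nM and a range from 3000 nM to 30000 nM, and a fair chance that only a limit is reported.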

Compound 4, concentration for 50% growth inhibition: 4030 nM
The estimate for compound 4 lay 2.2-fold (0.35 log units) above the measured number; the range from low to high includes it.
By their numbers in this assay, from the lowest: compounds 3, 2 and 4 (each within the scatter of the next).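

In this assay compound 1 gives "not active" (no number reported) and compound 4 gives 4030 nM so no step can be read between them. The compounds shown leave open what replacing 4-chlorophenyl with phenyl does to growth inhibition on this core. No measurement shown here offers an explanation for the result.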